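The source may hold more compounds than are shown below. What is called first, only, known or untested is meant among the compounds shown, and "the series" means these compounds.

Of the compounds shown here, three have been measured so far, each carrying a chlorine-bearing phenyl group on a saturated chain carbon bound to an amine nitrogen in a ring. In an assay on HEK293 cells for displacement of a labelled ligand from D(4) dopamine receptor (Homo sapiens) (on this read-out higher numbers stand for weaker inhibition and lower numbers for stronger inhibition), compound 1 `Clc1ccc2[nH]c(C3=CCN(Cc4ccccc4)CC3)nc2c1` gives 26 nM. In this assay compound 2 `Clc1ccc(CN2CC=C(c3nc4cc(Cl)ccc4s3)CC2)cc1` gives 21 nM. In this assay compound 3 `Clc1ccccc1CN1CC=C(c2nc3ccccc3s2)CC1` gives 87 nM, the highest number of the three: compound 1 lies nearest, at a lower number by a margin beyond the scatter, and compound 2 furthest, also lower by a margin beyond the scatter.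

Compound 4 `Clc1ccc(CN2CC=C(c3nc4ccccc4s3)CC2)cc1` has not yet been measured in this assay. It differs from compound 3 in one place: 4-chlorophenyl in place of 2-chlorophenyl on a saturated chain carbon bound to an amine nitrogen in a ring. For the measured compounds named here, no pair of measured compounds differs by this change alone, so the size of this step cannot be read from the data. Compound 2, which also carries the 4-chlorophenyl group on that carbon but differs elsewhere, gives 21 nM. On that basis the step of a 2.2-fold lower number from compound 3 to compound 4 (0.34 log units; beyond the scatter) is expected to run toward a lower number, of modest size, and it may yet fall within the scatter. Compound 4 is accordingly estimated at 40 nM, with a range from 15 nM to 100 nM.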

Compound 4, inhibition constant: 1.3 nM
Compound 4: the middle estimate sits 31-fold (1.49 log units) above what was measured; measured number outside the range, below it.
By their numbers in this assay, from the lowest: compound 4; then compounds 2 and 1 (each within the scatter of the next); then compound 3.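

In this assay this position, on a saturated chain carbon bound to an amine nitrogen in a ring, proves highly sensitive to the placement of the chlorine: 4-chlorophenyl in place of 2-chlorophenyl gives a 67-fold lower number from compound 3 to compound 4 (1.83 log units; beyond the scatter) with no change in the atoms present. The second step shows that the low number of compound 4 does not come from the 4-chlorophenyl group alone, since hydrogen in place of chloro on an aromatic carbon gives a 16-fold lower number from compound 2 to compound 4 (1.21 log units; beyond the scatter) even with that group held constant. Nothing in the data accounts for either step.

From the compounds shown here alone, whether the 4-chlorophenyl group has a similar effect on the core of compound 1 remains open, as that core appears here only with an unsubstituted phenyl group on the same carbon. Also open, going by these compounds, is whether a fluorine, a bromine, a methoxy group or a nitrile in place of the chlorine of the 4-chlorophenyl group would keep the number as low as in compound 4.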